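A 4-Cyanophenyl Group Replaces Two Four-Membered Rings

The source may hold more compounds than are shown below. What is called first, only, known or untested is meant among the compounds shown, and "the series" means these compounds.

Of the compounds shown here, two sharing the same core have been measured so far. In a physicochemical assay for solubility, measured as kinetic solubility, at pH 6.5 (a lower number here means a less soluble compound, a higher number a more soluble compound), compound 1 `NC(=O)[C@@H](CCC(F)(F)F)N(CC12CC(c3ncon3)(C1)C2)S(=O)(=O)c1ccc(Cl)cc1` gives 216000 nM and compound 2 `N#CC12CC(CN([C@H](CCC(F)(F)F)C(N)=O)S(=O)(=O)c3ccc(Cl)cc3)(C1)C2` gives 272000 nM. Among the measured compounds shown here, the only measured step is a 1.3-fold higher number from compound 1 to compound 2 (0.10 log units; within the scatter), with cyano in place of 1,2,4-oxadiazol-3-yl on a saturated ring carbon. Compound 2 therefore stands level with compound 1 on these numbers.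

Compound 3 `N#Cc1ccc(CN([C@H](CCC(F)(F)F)C(N)=O)S(=O)(=O)c2ccc(Cl)cc2)cc1` departs from compound 2 in a different part of the structure: a group of 8 heavy atoms (7 carbon, 1 nitrogen; one six-membered aromatic ring of carbon only) in place of a group of 7 heavy atoms (6 carbon, 1 nitrogen; 2 four-membered non-aromatic rings of carbon only), on a saturated chain carbon bound to a sulfonamide nitrogen. The new 4-cyanophenyl group sits on a saturated chain carbon bound to a sulfonamide nitrogen. The measured step bears on this change only loosely, as both of its compounds keep the two four-membered non-aromatic rings of carbon only. For the measured compounds named here, no measured pair removes those rings or introduces a six-membered aromatic ring, so the size of the change rests on judgement. A lower number in this assay, beyond the scatter, is expected. The expected change is a 4.5-fold lower number from compound 2 to compound 3 (0.66 log units; beyond the scatter). Compound 3 is estimated at 60000 nM, with an expected range from 12000 nM to 220000 nM.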

Compound 3, solubility: 44500 nM
Beside the measured number, compound 3's estimate is 1.3-fold (0.13 log units) above it, within the range that was stated.
By their numbers in this assay, from the lowest: compound 3; then compounds 1 and 2 (each within the scatter of the next).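

In this assay, the place on a saturated chain carbon bound to a sulfonamide nitrogen now proves able to move the number: 4-cyanophenyl in place of the group with 2 four-membered non-aromatic rings gives a 6.1-fold lower number from compound 2 to compound 3 (0.79 log units; beyond the scatter), whereas the earlier step, which kept those rings, stayed within the scatter. The same holds from the oxadiazole-bearing side, with a 4.9-fold lower number from compound 1 to compound 3 (0.69 log units; beyond the scatter), so compound 3 sits lowest of the three whichever of the two ring-bearing compounds it is read against, and the changed groups of compound 2 and compound 3 match in their triple bond and in their counts of hydrogen-bond donors and acceptors while differing in ring type and by one carbon. Nothing else measured here bears on why the number falls.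

The compounds shown leave open whether the lower number goes with the six-membered aromatic ring itself or with the nitrile it carries, which a plain phenyl or a cyclohexyl group at this place would help to separate. Also open, going by these compounds, is how a carboxylic acid or an aminomethyl group in place of the nitrile on that ring would read in this assay.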